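A few compounds are considered here, and "the series" means these few. Any claim that something is new, unique, unknown or untested is made for them only; others in the source may bear on it.

Measured in a functional assay on OVCAR-5 cells (Homo sapiens) for inhibition; a higher number here means a weaker inhibitor of growth, a lower number a stronger inhibitor of growth:
- compound 1 `Cc1cc(-c2nc3ccc(F)cc3s2)ccc1N`: > 100000 nM
- compound 2 `Nc1ccc(-c2nc3ccccc3s2)cc1C(F)(F)F`: 17400 nM
- compound 3 `Nc1ccc(-c2nc3ccccc3s2)cc1F`: < 10 nM

The value of compound 3 is a limit and not a number: the limit of < 10 nM in this assay, at which 1 of the 3 values shown sits. The value of compound 1 is also a limit: the limit of > 100000 nM in this assay, at which 1 of the 3 values shown sits.

Compound 4 `Cc1cc(-c2nc3ccccc3s2)ccc1N` is the next case. It has methyl in place of fluoro on an aromatic carbon, ortho to an amino group: methyl in place of fluoro on an aromatic carbon.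

The closest measured change is an at least 1700-fold lower number from compound 2 to compound 3 (3.24 log units; beyond the scatter). It replaces trifluoromethyl with fluoro, also ortho to an amino group, and shows that a single swap there can shift the number by a large amount. It does not show how methyl behaves. For the measured compounds named here, the only measured compound with this methyl is compound 1, whose core also carries a further fluoro, and it gives > 100000 nM. That value is a limit, and it argues for caution, as no value is available for methyl on the unchanged core.

A moderate move towards a higher number is therefore expected, with a wide margin and a real chance of another limit. The estimated change is an at least 2.0-fold higher number from compound 3 to compound 4 (0.30 log units; that floor lies within the scatter).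

For compound 4 the expected value is 20 nM, with an estimated range of 2 nM to 2000 nM.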

Compound 4, concentration for 50% growth inhibition: 1900 nM
For compound 4 the middle estimate is 95-fold (1.98 log units) below the measured one; the range from low to high includes it.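

In this assay, methyl in place of fluoro, ortho to an amino group, gives an at least 190-fold higher number from compound 3 to compound 4 (2.27 log units; beyond the scatter), while methyl in place of trifluoromethyl gives a 9.2-fold lower number from compound 2 to compound 4 (0.96 log units; beyond the scatter), so on the shared core the number at this position runs from fluoro through methyl to trifluoromethyl, and methyl now sits between the two groups compared earlier. Compound 3 stands at a limit and not at a number, which makes the size of its step to compound 4 a floor: the limit of < 10 nM in this assay, at which 1 of the 4 values shown sits. The high number of compound 1 is also not carried by methyl alone, since hydrogen in place of fluoro on the core of compound 1 gives an at least 52-fold lower number from compound 1 to compound 4 (1.72 log units; beyond the scatter), again a floor, as compound 1 stands at a limit: the limit of > 100000 nM in this assay, at which 1 of the 4 values shown sits.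

The order rests on three groups only, and a chlorine, a methoxy group, a nitrile or plain hydrogen at this position would show whether fluoro stands apart or merely heads a wider trend. From the compounds shown here alone, the effect of the further fluoro on the core is read only with methyl present, so its size with fluoro at this position stays open.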